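Aminophenyl pyrimidinone series: ester with pentyloxy replacing amino

The compounds below may be only part of what the source reports. "The series", "measured", "known", "first", "only" and "open" are said of these compounds alone.

Measured so far in a functional assay on the whole organism (strain Sprague-Dawley) for inhibition, with Rattus norvegicus as the target, with a stated time of 10 min; on this read-out lower numbers stand for an effect already at smaller amounts and higher numbers for an effect only at larger amounts of compound:
- compound 1 `Nc1ccccc1-c1ncc(C(=O)O)c(=O)[nH]1`: 50 mg/kg
- compound 2 `CCOc1ccc(N)cc1-c1ncc(C(=O)O)c(=O)[nH]1`: 1.2 mg/kg
- compound 3 `CCOC(=O)c1cnc(-c2ccccc2N)[nH]c1=O`: "not determined" (no result reported)

Compound 3 carries the ethyl ester of the acid found in compound 1, with the same aminophenyl attached to the shared core. In this assay compound 3 has no result reported, so it cannot be placed against compound 1 or compound 2 by any number. Among the two measured compounds, compound 2 gives 1.2 mg/kg and compound 1 gives 50 mg/kg; these two values lie far apart, beyond the scatter, and the pair differs by an ethoxy group, not by a single change that maps onto the step considered here.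

Compound 4 `CCCCCOc1ccccc1-c1ncc(C(=O)OCC)c(=O)[nH]1` follows from compound 3 by pentyloxy in place of amino on an aromatic carbon. Since compound 3 has no number, no step size can be computed; the expectation for compound 4 is therefore anchored only loosely, between the values of compound 1 and compound 2, with a wide band. For compound 4 in this assay the dose is estimated at 10 mg/kg, expected to fall within 2 mg/kg to 60 mg/kg.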

Compound 4, dose for 50% inhibition: 2 mg/kg
The estimate for compound 4 lay 5.0-fold (0.70 log units) above the measured number, and the stated range covers the measured number.
By their numbers in this assay, from the lowest: compounds 2 and 4 (each within the scatter of the next); then compound 1.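

Among these compounds, compound 3 has no reported result in this assay, and compound 4 gives 2 mg/kg, so no step from compound 3 to compound 4 can be read. No supporting data bear on this result. The compounds shown leave open how pentyloxy in place of amino shifts the dose on its own, and how the ethyl ester compares with the acid of compound 1.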